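Working notes: the step from compound 3 to compound 4

The compounds below may be only part of what the source reports. "The series", "measured", "known", "first", "only" and "open" are said of these compounds alone.

Compound 3 (`C=C[C@@](C)(/C=C/c1ccc(O)cc1)CCC(O)C(C)(C)O`) gives > 36600 nM in an ADME assay on HEK293 cells (Homo sapiens) for cytotoxicity, with a stated time of 72 h (a higher number here means that more compound is needed for the effect, a lower number that less compound is needed), as a limit and not a number. Compound 1 (`C=C[C@@](C)(/C=C/c1ccc(OC)cc1)CCC=C(C)C`) gives > 36600 nM as a limit too. Compound 2 (`C=C[C@](C)(CCCC(C)C)CCc1ccc(O)cc1`) gives > 36600 nM as a limit too. For the measured compounds named here, the series so far therefore stands at the limit of > 36600 nM in this assay, at which 3 of the 3 values shown sit, and offers no number that sets compound 3 apart from the others.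

Going by the values given here, compound 4 (`C=C[C@@](C)(/C=C/c1ccc(O)cc1)CC/C=C(C)/C=N/N`) differs from compound 3 by a group of 6 heavy atoms (4 carbon, 2 nitrogen; no ring) in place of a group of 6 heavy atoms (4 carbon, 2 oxygen; no ring), on a saturated chain carbon, three bonds along the chain from two double-bonded chain carbons as its one change. The 1,2-dihydroxy-2-methylpropyl group leaves, and the entering group has 2 double bonds outside aromatic rings.

Among the compounds with values here, no measured pair shows a change of this kind. A small step towards less compound needed in this assay is expected, possibly none beyond the scatter. That expectation rests on compound 3 at > 36600 nM as a limit. The expected size is an at least 1.3-fold lower number from compound 3 to compound 4 (0.11 log units; that floor lies within the scatter) as a rough figure. The estimate for compound 4 is 28000 nM with an expected range from 9000 nM to 60000 nM in this assay.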

Compound 4, half-maximal effective concentration: > 36600 nM
Compound 4 was reported as a limit; the forecaster's own chance of this, stated with the estimate: 60%; middle value at least 1.3-fold (0.11 log units) from the limit.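

In this assay compound 4 gives > 36600 nM, a limit and not a number, so no step can be read between compound 3 and compound 4: the limit of > 36600 nM in this assay, at which 4 of the 4 values shown sit.

The compounds shown leave open whether they differ at all in this assay, and which structural change, if any, would give a measured number.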